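A few compounds are considered here, and "the series" means these few. Any claim that something is new, unique, unknown or untested is made for them only; others in the source may bear on it.

In a functional assay on A549 cells (Homo sapiens) for antiproliferative activity, read by MTT assay, with a stated time of 72 h (a higher number here means a weaker inhibitor, a lower number a stronger inhibitor), compound 1 (`Cn1cc(-c2nn(Cc3ccc(C(=O)N4CCCCC4)cc3)c(=O)c3ccccc23)cn1`) gives 67400 nM, compound 2 (`CN1CCC(NC(=O)c2ccc(Cn3nc(-c4cnn(C)c4)c4ccccc4c3=O)cc2)CC1`) gives 54300 nM, and compound 3 (`Cc1noc(C)c1-c1nn(Cc2ccc(C(=O)N3CCCCC3)cc2)c(=O)c2ccccc12`) gives 86200 nM, so all three values lie within the scatter of one another. Compound 4 (`Cc1noc(C)c1-c1nn(Cc2ccc(C(=O)NC3CCN(C)CC3)cc2)c(=O)c2ccccc12`) is still unmeasured and differs from compound 3 by (1-methylpiperidin-4-yl)amino in place of piperidin-1-yl on a carbonyl carbon. Among the measured compounds shown here, the same exchange on the 1-methyl-1H-pyrazol-4-yl member of the series gave a 1.2-fold lower number from compound 1 to compound 2 (0.09 log units; within the scatter), which is the closest precedent. Replacing 1-methyl-1H-pyrazol-4-yl with 3,5-dimethyl-1,2-oxazol-4-yl gave a 1.3-fold higher number from compound 1 to compound 3 (0.11 log units; within the scatter). Neither step exceeds the scatter, so no step beyond the scatter is expected in this assay. The expected step is a 1.2-fold lower number from compound 3 to compound 4 (0.09 log units; within the scatter). For compound 4 the estimate is 70000 nM, with an expected range of 36000 nM to 135000 nM.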

Compound 4, half-maximal inhibitory concentration: > 100000 nM
Compound 4: a limit, no number (the forecaster's own chance of this, stated with the estimate: 10%); middle value at least 1.4-fold (0.15 log units) away from the limit.
By their numbers in this assay, from the lowest: compounds 2, 1 and 3 (each within the scatter of the next). At a limit, above all of these: compound 4.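

In this assay compound 4 stands at a limit of the assay, > 100000 nM, the first such limit in this series. With (1-methylpiperidin-4-yl)amino in place of piperidin-1-yl on the carbonyl carbon, the 3,5-dimethyl-1,2-oxazol-4-yl member gives only a floor, an at least 1.1-fold higher number from compound 3 to compound 4 (0.06 log units; that floor lies within the scatter), and the exchange of the aromatic group likewise gives only a floor, an at least 1.8-fold higher number from compound 2 to compound 4 (0.26 log units; that floor lies within the scatter). The carbonyl change has now been seen on two cores, with no difference between them established: the same change on two cores in this assay, a 1.2-fold lower number (0.09 log units; within the scatter) from compound 1 to compound 2 and an at least 1.1-fold higher number (0.06 log units; that floor lies within the scatter) from compound 3 to compound 4; the limit leaves it open whether they differ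

How far compound 4 lies past its limit cannot be read. Also open, on these data alone, is whether morpholin-4-yl or dimethylamino on the carbonyl carbon would move the number beyond the scatter.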